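The source may hold more compounds than are shown below. What is called first, only, known or untested is meant among the compounds shown, and "the series" means these compounds.

Compound 1 `O=C1N=C(Nc2ccc(S(=O)(=O)Nc3nccs3)cc2)S/C1=C/c1coc2ccccc2c1=O` was examined in a functional assay on A549 cells (Homo sapiens) for cytotoxicity, read by sulforhodamine B assay, with a stated time of 72 h; a lower number here means a stronger inhibitor, a higher number a weaker inhibitor. For compound 1 this assay reports only a limit, > 100000 nM, and not a number. Among the compounds with values here, the only other measured compound, compound 2 `Cc1cc(C)nc(NS(=O)(=O)c2ccc(N3C(=O)/C(=C/c4coc5ccccc5c4=O)N=C3c3ccc(Cl)cc3)cc2)n1`, gives 52600 nM in this assay. Compound 1 therefore stands at the edge of what the assay can resolve, as the evidence notes: the limit of > 100000 nM in this assay, at which 1 of the 2 values shown sits. Compound 3 `Cc1cc(NS(=O)(=O)c2ccc(NC3=NC(=O)/C(=C\c4coc5ccccc5c4=O)S3)cc2)no1` has not yet been measured. It differs from compound 1 in one place: 5-methyl-1,2-oxazol-3-yl in place of 1,3-thiazol-2-yl on a sulfonamide nitrogen. Within the data shown here, no measured pair shows this change, so the size of the step is unknown from the data. The author expects no step beyond the usual scatter, a number no higher from compound 1 to compound 3 (the limit leaves the size open), with compound 3 remaining near the limit. Compound 3 is therefore estimated at 100000 nM in this assay, between 40000 nM and 300000 nM, and quite possibly reported again only as a limit.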

Compound 3, half-maximal inhibitory concentration: > 100000 nM
Compound 3: a limit, no number; the forecaster's own chance of this, stated with the estimate: 60%; the middle value sits exactly at the limit.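

In this assay compound 3 gives > 100000 nM, a limit and not a number. Within the data shown here, compound 1 also has only a limit, so no step between compound 1 and compound 3 can be read. The compounds shown leave open whether 5-methyl-1,2-oxazol-3-yl in place of 1,3-thiazol-2-yl on a sulfonamide nitrogen changes the value at all.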